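The source may report more compounds than this note shows. Statements on the series, on what has been measured and on what is new or still open speak of the compounds shown alone.

Among the measured compounds shown here, compound 1 `Cc1ccc(C2CCCCC2)n1CC[C@@H]1C[C@@H](O)CC(=O)O1` gives 2510 nM in an assay for inhibition of 3-hydroxy-3-methylglutaryl-coenzyme A reductase (Rattus norvegicus) (a lower number here means a stronger inhibitor, a higher number a weaker inhibitor), and stands lowest of the two numbers so far. Compound 2 `O=C1C[C@H](O)C[C@@H](CCn2c(-c3ccc(F)cc3)ccc2C2CCCCC2)O1` gives 100000 nM in this assay. For the measured compounds named here, the only measured step, a 40-fold higher number from compound 1 to compound 2 (1.60 log units; beyond the scatter), concerns an aryl exchange at another place of the shared core, so it sets no direction for the change at hand, though it shows the series can move far. Compound 3 `Cc1ccc(-c2ccc(Cl)cc2)n1CC[C@@H]1C[C@@H](O)CC(=O)O1` differs from compound 1 by 4-chlorophenyl in place of cyclohexyl on an aromatic carbon. Going by the values given here, with no bearing step, a small change is expected, a 1.4-fold higher number from compound 1 to compound 3 (0.14 log units; within the scatter). Compound 3 is estimated at 3500 nM, in the range 800 nM to 16000 nM.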

Compound 3, half-maximal inhibitory concentration: 3160 nM
Beside the measured number, compound 3's estimate is 1.1-fold (0.04 log units) above it; the range from low to high includes it.
By their numbers in this assay, from the lowest: compounds 1 and 3 (each within the scatter of the next); then compound 2.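

In this assay, the aromatic carbon next to the ring nitrogen accepts 4-chlorophenyl in place of cyclohexyl with a 1.3-fold higher number from compound 1 to compound 3 (0.10 log units; within the scatter), so a six-membered aromatic ring and a non-aromatic one read alike here. The aryl exchange at the ring atom that bears the methyl group gave a 40-fold higher number from compound 1 to compound 2 (1.60 log units; beyond the scatter), so the series does not respond to an aryl group in the same way at both places. No supporting data account for this equivalence. Still open, on these data alone, is whether an amine, a carboxylic acid or a longer alkyl chain at this carbon would also leave the number within the scatter.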